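The compounds below may be only part of what the source reports. "The series", "measured", "known", "first", "only" and "open" are said of these compounds alone.

In a toxicity assay on L02 cells (Homo sapiens) for cytotoxicity, read by MTT assay, with a stated time of 72 h (on this read-out lower numbers stand for stronger inhibition and higher numbers for weaker inhibition), compound 2 (`CC1(C)OCC(Cn2cc(Cn3c4c(c5ccccc53)C(=O)c3c[n+]([O-])c5ccccc5c3C4=O)nn2)O1`) gives 120 nM and stands at the low end of the series together with compound 1 (`CN(C)CCCCCn1c2c(c3ccccc31)C(=O)c1c[n+]([O-])c3ccccc3c1C2=O`), which gives 240 nM. These two values lie within the scatter of each other. Compound 3 (`O=C1c2c[n+]([O-])c3ccccc3c2C(=O)c2c1c1ccccc1n2CCN1CCCCC1`) sits apart from both at 1050 nM, beyond the scatter.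

Compound 4 (`O=C1c2c[n+]([O-])c3ccccc3c2C(=O)c2c1c1ccccc1n2Cc1cn([C@@H]2O[C@H](CO)[C@@H](O)[C@H](O)[C@H]2O)nn1`) differs from compound 2 at one place: 3,4,5-trihydroxy-6-(hydroxymethyl)oxan-2-yl in place of (2,2-dimethyl-1,3-dioxolan-4-yl)methyl on an aromatic nitrogen. The exchange lies on an aromatic nitrogen of a five-membered aromatic ring with 3 nitrogen.

Within the data shown here, no measured pair changes the group at this place. Among the measured compounds shown here, the only measured step, a 4.4-fold higher number from compound 1 to compound 3 (0.64 log units; beyond the scatter), is a side-chain exchange elsewhere on the shared core and bears on this change only indirectly. For the measured compounds named here, with that step as the sole guide, a modest move to a higher number is expected in this assay, although a result within the scatter remains possible. The expected change is a 2.9-fold higher number from compound 2 to compound 4 (0.46 log units; beyond the scatter). For compound 4 the estimated value is 350 nM, with an expected range from 100 nM to 1300 nM.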

Compound 4, half-maximal inhibitory concentration: 420 nM
Compound 4: the middle estimate sits 1.2-fold (0.08 log units) below what was measured, and the stated range covers the measured number.
By their numbers in this assay, from the lowest: compounds 2, 1 and 4 (each within the scatter of the next, the first and the last beyond it); then compound 3.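

Among these compounds, this is the first measured exchange on the aromatic nitrogen of the five-membered aromatic ring with 3 nitrogen: in this assay, 3,4,5-trihydroxy-6-(hydroxymethyl)oxan-2-yl in place of (2,2-dimethyl-1,3-dioxolan-4-yl)methyl gives a 3.5-fold higher number from compound 2 to compound 4 (0.54 log units; beyond the scatter) on this read-out, so the group at this place does register. The entering group has 11 heavy atoms, 4 hydrogen-bond donors and 5 defined stereocentres, against 8 heavy atoms and 0 donors in the leaving group, and this single step cannot separate these differences. No measurement available here bears on the reason for the step.

Still open, from the compounds shown here alone, is how a carboxylic acid, an amine or a plain longer chain on this aromatic nitrogen would read in this assay against these two groups. Also open, going by these compounds, is whether the arrangement of the stereocentres matters, as only one arrangement appears here.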